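The source may hold more compounds than are shown below. What is called first, only, known or untested is meant among the compounds shown, and "the series" means these compounds.

Compounds measured so far:
Compound 1 `O=C1C=CC2(C=C1)OCCC(=O)N2c1ccccc1` gives 1300 nM in a functional assay on BV-2 cells (Mus musculus), read by Griess assay, with a stated time of 24 h; a lower number here means a stronger inhibitor, a higher number a weaker inhibitor.
Compound 2 `CC1COC2(C=CC(=O)C=C2)N(c2ccccc2)C1=O` gives 1220 nM.
Compound 3 `C=CCCC1COC2(C=CC(=O)C=C2)N(c2ccccc2)C1=O` gives 730 nM.

Compound 1 stands highest of the three numbers, but its gaps to compound 2 and compound 3 are both within the scatter a 1.1-fold lower number from compound 1 to compound 2 (0.03 log units; within the scatter) a 1.8-fold lower number from compound 1 to compound 3 (0.25 log units; within the scatter).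

Compound 4 `O=C1C=CC2(C=C1)OCC(Cc1ccc(Cl)cc1)C(=O)N2c1ccccc1` differs from compound 1 by 4-chlorobenzyl in place of hydrogen on a saturated ring carbon. The two steps that bear on it put methyl and but-3-en-1-yl at this same saturated ring carbon; both gave lower numbers, yet neither left the scatter. A larger group enters here, and the account therefore expects at most a modest lowering, quite possibly none beyond the scatter.

For compound 4 the estimate is 750 nM, with a range from 300 nM to 1900 nM, meaning an expected step of a 1.7-fold lower number from compound 1 to compound 4 (0.24 log units; within the scatter).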

Compound 4, half-maximal inhibitory concentration: 540 nM
Compound 4: middle estimate off by 1.4-fold (0.14 log units), on the high side; measured number inside the range.
By their numbers in this assay, from the lowest: compounds 4, 3, 2 and 1 (each within the scatter of the next, the first and the last beyond it).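

In this assay, among the compounds shown here, the 4-chlorobenzyl group is the first change at this saturated ring carbon to leave the scatter (a 2.4-fold lower number from compound 1 to compound 4 (0.38 log units; beyond the scatter)). Against the methyl group the step also leaves the scatter (a 2.3-fold lower number from compound 2 to compound 4 (0.35 log units; beyond the scatter)), but against the but-3-en-1-yl group it does not (a 1.4-fold lower number from compound 3 to compound 4 (0.13 log units; within the scatter)). No evidence at hand accounts for these steps. On these data alone, what a plain benzyl group, an amine or a carboxylic acid would do at this ring carbon remains open, as does any part played by the chlorine.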